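The compounds below may be only part of what the source reports. "The series", "measured", "known", "first", "only" and "open" are said of these compounds alone.

Measured so far, in a functional assay on A549 cells (Homo sapiens) for cytotoxicity, read by MTT assay, with a stated time of 48 h; a higher number here means a weaker inhibitor, a lower number a stronger inhibitor:
Compound 1, `Cc1ccc(S(=O)(=O)/N=C(/CCNC2=CC(=O)c3ccccc3C2=O)Nc2cccc(C)c2)cc1`: compound 1 gives 18700 nM
Compound 2, `Cc1ccc(S(=O)(=O)/N=C(/CCNC2=CC(=O)c3ccccc3C2=O)Nc2ccc(F)c(F)c2)cc1`: compound 2 gives 16700 nM

Compound 2 has the lower of the two numbers, but the step of a 1.1-fold lower number from compound 1 to compound 2 (0.05 log units; within the scatter) is within the scatter, so the two compounds cannot be told apart on these data. Compound 3, `COc1ccc(N/C(CCNC2=CC(=O)c3ccccc3C2=O)=N\S(=O)(=O)c2ccc(C)cc2)c(OC)c1`, carries the change (2,4-dimethoxyphenyl in place of 3,4-difluorophenyl on an amine nitrogen). Among the compounds with values here, the only measured step, a 1.1-fold lower number from compound 1 to compound 2 (0.05 log units; within the scatter), also swaps the ring on that amine nitrogen and produced no change beyond the scatter; nothing measured speaks to the two methoxy groups themselves. The step from compound 2 to compound 3 is therefore expected to be small, a 1.0-fold higher number from compound 2 to compound 3 (0.01 log units; within the scatter), with no direction favoured. Compound 3 is expected to give about 17000 nM in this assay, with a likely range from 7000 nM to 40000 nM.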

Compound 3, half-maximal inhibitory concentration: 126000 nM
Beside the measured number, compound 3's estimate is 7.4-fold (0.87 log units) below it; measured number outside the range, above it.
By their numbers in this assay, from the lowest: compounds 2 and 1 (each within the scatter of the next); then compound 3.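

The ring on this amine nitrogen turns out not to be a silent position. In this assay, 2,4-dimethoxyphenyl brings a step beyond the scatter whichever ring it replaces (a 7.5-fold higher number from compound 2 to compound 3 (0.88 log units; beyond the scatter); a 6.7-fold higher number from compound 1 to compound 3 (0.83 log units; beyond the scatter)), whereas the earlier swap between 3-methylphenyl and 3,4-difluorophenyl showed nothing beyond the scatter, and compound 3 is now the weakest of the three. The position therefore accepts two different rings about equally but not this third one, and nothing available explains the loss.

On these data alone, the two methoxy groups enter together, so it remains open whether a single methoxy group on the ring would bring the same step. As far as these compounds go, it is also open how a plain phenyl ring, or a ring carrying an amine or a carboxylic acid, would compare.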